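The source may hold more compounds than are shown below. What is called first, only, known or untested is meant among the compounds shown, and "the series" means these compounds.

Compound 1 `Cc1cc(C)c(S(=O)(=O)N2CCC(N3CCC(CCO)CC3)CC2)c(C)c1`: 19 nM
Compound 2 `Cc1cc(C)c(S(=O)(=O)N2CCC(N3CCC(C(C)C)CC3)CC2)c(C)c1`: 0.3 nM
Compound 3 `Cc1cc(C)c(S(=O)(=O)N2CCC(N3CCC(c4ccccc4)CC3)CC2)c(C)c1`: 865 nM

All three were compared in a functional assay on DLD-1 cells (Homo sapiens) for antiproliferative activity, read by CellTiter-Glo, with a stated time of 72 h; a higher number here means a weaker inhibitor, a lower number a stronger inhibitor. Compound 2 holds the lowest number of the three, and the steps of a 63-fold lower number from compound 1 to compound 2 (1.80 log units; beyond the scatter), a 2900-fold higher number from compound 2 to compound 3 (3.46 log units; beyond the scatter) and a 46-fold higher number from compound 1 to compound 3 (1.66 log units; beyond the scatter) all lie beyond the scatter. Compound 4 `Cc1cc(C)c(S(=O)(=O)N2CCC(N3CCCCCC3)CC2)c(C)c1` differs from compound 2 in that (azepan-1-yl in place of 4-isopropylpiperidin-1-yl on a saturated ring carbon). Among the measured compounds shown here, no measured step makes this exact change, yet each of the three steps alters only what sits on a saturated ring carbon, and each moved this assay by a large amount, so the group removed in compound 4 carries much weight. A large step upward is therefore expected, a 100-fold higher number from compound 2 to compound 4 (2.00 log units; beyond the scatter). Compound 4 is expected to give about 30 nM, within a range from 3 nM to 300 nM.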

Compound 4, half-maximal inhibitory concentration: 5.3 nM
Beside the measured number, compound 4's estimate is 5.7-fold (0.75 log units) above it, within the range that was stated.
By their numbers in this assay, from the lowest: compound 2; then compound 4; then compound 1; then compound 3.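

Azepan-1-yl in place of 4-isopropylpiperidin-1-yl gives an 18-fold higher number from compound 2 to compound 4 (1.25 log units; beyond the scatter) in this assay, so the seven-membered ring does not match compound 2. The same ring still improves on the 2-hydroxyethyl group, with a 3.6-fold lower number from compound 1 to compound 4 (0.55 log units; beyond the scatter) in that assay. This position therefore accepts a change of ring size as well as of substituent, and no available evidence explains either shift. The compounds shown leave open how an unsubstituted piperidin-1-yl or a pyrrolidin-1-yl group would read in this assay, and so whether ring size or the isopropyl group drives the larger step.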